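The source may hold more compounds than are shown below. What is called first, only, known or untested is meant among the compounds shown, and "the series" means these compounds.

Of the compounds shown here, three built on the same core have been tested in an assay on cells for inhibition of thyroid peroxidase (Homo sapiens), with stated times of 10 min and 15 min; a lower number here means a stronger inhibitor, a higher number a weaker inhibitor. Compound 1 `Nc1cc(Cc2ccn(Cc3cccc(-c4ccccc4)c3)n2)c2nn[nH]c2n1` gives 1100 nM. Compound 2 `Nc1cc(Cc2ccn(Cc3cccc(Oc4cccc5c4CNC5)c3)n2)c2nn[nH]c2n1` gives 1700 nM, and compound 3 `Nc1cc(Cc2ccn(Cc3ccc4cnccc4c3)n2)c2nn[nH]c2n1` gives 1800 nM. Among these three numbers compound 2 stands second highest: its nearest neighbour is compound 3 and its furthest is compound 1, and both gaps lie within the scatter of this assay, so the three compounds cannot be separated by potency on these data.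

Within the data shown here, only one step between measured compounds changes a single place: a 1.5-fold higher number from compound 1 to compound 2 (0.19 log units; within the scatter), where a larger group replaced a smaller one on an aromatic carbon without moving the number beyond the scatter.

Compound 4 `Nc1cc(Cc2ccn(Cc3cccc(C4CCNCC4)c3)n2)c2nn[nH]c2n1` has not yet been measured. It differs from compound 2 in one place: a group of 6 heavy atoms (5 carbon, 1 nitrogen; one six-membered non-aromatic ring with 1 hetero atom) in place of a group of 10 heavy atoms (8 carbon, 1 nitrogen, 1 oxygen; one five-membered non-aromatic ring with 1 hetero atom, one six-membered aromatic ring of carbon only), on an aromatic carbon. Among the measured compounds shown here, the measured step from compound 1 to compound 2 is the only guide to what exchanging groups at this aromatic carbon does, and it was small. For the measured compounds named here, no measured compound carries a piperidin-4-yl group, so the expectation rests on that single step alone. For compound 4 the expected number in this assay is therefore 1500 nM, with an estimated range from 600 nM to 4000 nM. The implied step, a 1.1-fold lower number from compound 2 to compound 4 (0.05 log units; within the scatter), is expected to stay within the scatter.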

Compound 4, half-maximal inhibitory concentration: 21000 nM
Estimate against measurement, compound 4: 14-fold (1.15 log units) below, and the stated range ends below it.
By their numbers in this assay, from the lowest: compounds 1, 2 and 3 (each within the scatter of the next); then compound 4.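

In this assay, the group on this aromatic carbon, meta to a large group, clearly matters: piperidin-4-yl in place of the larger group of compound 2 gives a 12-fold higher number from compound 2 to compound 4 (1.09 log units; beyond the scatter), and piperidin-4-yl in place of phenyl gives a 19-fold higher number from compound 1 to compound 4 (1.28 log units; beyond the scatter). Among these compounds, the earlier step, a 1.5-fold higher number from compound 1 to compound 2 (0.19 log units; within the scatter), stayed within the scatter, which made exchanges here look harmless, but both of those groups hold a six-membered aromatic ring of carbon only, and piperidin-4-yl is the first group here without one. Size by heavy-atom count does not sort these results, since phenyl and piperidin-4-yl have the same count and still sit far apart, while the larger group of compound 2 stays within the scatter of phenyl; no measurement at hand explains the difference.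

Going by these compounds, it remains open whether the loss of the aromatic ring or the presence of the ring nitrogen goes with the higher number. Cyclohexyl at this carbon would test the first without the nitrogen, and a pyridinyl ring would place a nitrogen in an aromatic ring, so the two could be told apart.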